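A few compounds are considered here, and "the series" means these few. Any claim that something is new, unique, unknown or untested is made for them only; others in the source may bear on it.

Working notes on the series. Compound 1 `CCC(=O)N[C@@H]1CCCc2c1cncc2N1Cc2cc(Cl)ccc2C1=O` gives 2.14 in a physicochemical assay for lipophilicity, measured as octanol-water partition; on this read-out higher numbers stand for higher lipophilicity and lower numbers for lower lipophilicity. Going by the values given here, compound 2 `N#Cc1ccc2c(c1)CN(c1cccnc1)C2=O` gives 1.35 in this assay, the lower of the two values so far, and its gap to compound 1 lies beyond the usual scatter. Compound 3 `O=C1c2ccc(Cl)cc2CN1c1cccnc1` has not yet been measured in this assay. It differs from compound 2 in one place: chloro in place of cyano on an aromatic carbon. Among the compounds with values here, no measured pair of this kind is available, so the expectation rests on the structural change alone. An upward step is expected, a number 1.15 log units higher from compound 2 to compound 3 (beyond the scatter), beyond the scatter. For compound 3 a value of 2.5 is estimated, expected to fall between 2 and 3.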

Compound 3, distribution coefficient: 2.52
Estimate against measurement, compound 3: 0.02 log units below; the range from low to high includes it.
By their numbers in this assay, from the lowest: compound 2; then compound 1; then compound 3.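

In this assay, going by these compounds alone, the exchange of cyano for chloro on an aromatic carbon gives a number 1.17 log units higher from compound 2 to compound 3 (beyond the scatter) and so provides the first single-place step. This puts a size on the exchange at this position, on the six-membered aromatic ring of carbon only, which the earlier values could not do, since compound 1 and compound 2 differ in more than one place. Nothing measured here bears on the origin of this step. 

Whether the step carries over to the core of compound 1 remains open, as that core is shown only with chloro. From the compounds shown here alone, how an amine, a carboxylic acid or a methoxy group would read at this position also remains open.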